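Taking the chain off the ring nitrogen of compound 1

This account rests on a few compounds, and the source may have more. Where it says the series, first, only, none or still open, it means among the compounds named here.

In a physicochemical assay for solubility, read by HPLC, at pH 6.5 (on this read-out lower numbers stand for lower solubility and higher numbers for higher solubility), compound 1 (`O=C1CC2(CCN(CCC3CCCCC3)CC2)Oc2c1ccc1ccccc21`) reads 10000 nM as its result. In this assay compound 2 (`c1ccc2c3c(ccc2c1)CCC1(CCNCC1)O3`) reads 20000 nM as its result. These two numbers lie within the usual scatter of repeated measurements, so compound 1 cannot be ranked against compound 2.

Compound 3 (`O=C1CC2(CCNCC2)Oc2c1ccc1ccccc21`) has not been measured yet. It is compound 1 with hydrogen in place of 2-cyclohexylethyl on an amine nitrogen in a ring. The group that leaves carries one six-membered non-aromatic ring of carbon only.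

For the measured compounds named here, no measured pair shows this change on its own, so any expectation here is loose. Going by the values given here, compound 2 also has hydrogen on an amine nitrogen in a ring, and its reading of 20000 nM is the only nearby guide. In this assay a modest upward move is expected, perhaps only just beyond the scatter, and the estimated 2.5-fold higher number from compound 1 to compound 3 (0.40 log units; beyond the scatter) remains a judgement. For compound 3 the expected value is 25000 nM with an estimated range (10000 nM to 70000 nM).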

Compound 3, solubility: >= 80000 nM
Compound 3: no number, only a limit (the forecaster's own chance of this, stated with the estimate: 10%); at least 3.2-fold (0.50 log units) between middle value and limit.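

In this assay, putting hydrogen in place of 2-cyclohexylethyl on the ring nitrogen gives an at least 8.0-fold higher number from compound 1 to compound 3 (0.90 log units; beyond the scatter). For the compounds shown here, this is the first step in the set that isolates a single change, and it shows that the group on this nitrogen matters for the reading, which the comparison of compound 1 with compound 2 could not show, as those two differ in more than one place and sit within the usual scatter. Compound 3 reads >= 80000 nM, which is a limit of the assay and not a number, so the step sets only a lower bound and its full size stays unknown: the limit of >= 80000 nM in this assay, at which 1 of the 3 values shown sits.

The compounds shown leave open whether the step belongs to the six-membered ring of the departing group or to the chain that carries it, a question that a plain ethyl chain or a methyl group on the same nitrogen would help to settle. They also leave open how a group of another kind on this nitrogen, such as a chain ending in a carboxylic acid or an amine, would read in this assay.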